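Extending compound 2 with a fluorinated styryl group

The source may hold more compounds than are shown below. What is called first, only, known or untested is meant among the compounds shown, and "the series" means these compounds.

In a functional assay on MCF7 cells (Homo sapiens) for cytotoxicity, read by MTT assay, with a stated time of 2 days, tested at 0.1 uM (a higher number here means a weaker effect of the compound at the concentration tested, a lower number a stronger effect), compound 2 `COc1ccc(-c2cc3cc(-c4ccccc4)cc(C(C)=O)c3[nH]2)cc1` gives 87%, the lowest of the three numbers in hand. Compound 1 `CC(=O)c1cc(-c2ccccc2)cc2cc(-c3ccc(F)cc3)[nH]c12` gives 98.5% and compound 3 `CC(=O)c1cc(/C=C/c2ccccc2)cc2cc(-c3ccc(F)cc3)[nH]c12` gives 98.4%, so the step of a number 11.5 percentage points lower from compound 1 to compound 2 (beyond the scatter) lies beyond the scatter, while the step of a number 0.1 percentage points lower from compound 1 to compound 3 (within the scatter) does not. Compound 4 `COc1ccc(-c2cc3cc(/C=C/c4ccc(F)cc4)cc(C(C)=O)c3[nH]2)cc1` is compound 2 with one change: 2-(4-fluorophenyl)ethenyl in place of phenyl on an aromatic carbon. Going by the values given here, the step that bears on this change is the one from compound 1 to compound 3, where a phenyl was likewise replaced by a 2-phenylethenyl group at the same position of the shared core and the number barely moved. Among the compounds with values here, the only further difference is the fluorine on the entering group, for which no directly comparable step exists. The account therefore expects no step beyond the scatter, with no change at the digits printed from compound 2 to compound 4 (within the scatter) as the estimated change. Compound 4 is estimated to give 87% in this assay, within a range from 77% to 97%.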

Compound 4, a percentage reported as activity, at one concentration (the size of the read-out at that concentration, not a potency): 97.2%
For compound 4 the middle estimate is 10.2 percentage points below the measured one; the measured number lies above the stated range.
By their numbers in this assay, from the lowest: compound 2; then compounds 4, 3 and 1 (each within the scatter of the next).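

At the position meta to the acetyl group, the swap of phenyl for 2-(4-fluorophenyl)ethenyl in this assay gives a number 10.2 percentage points higher from compound 2 to compound 4 (beyond the scatter), so this position is not indifferent to change in the methoxy-bearing compounds. The earlier step of the same kind, a number 0.1 percentage points lower from compound 1 to compound 3 (within the scatter), came with the fluoro substituent on the other aryl ring and an entering group without fluorine, and it gave no sign of this sensitivity. No measurement shown here accounts for the step.

The compounds shown leave open whether the ethenyl link or the fluorine on the entering group carries the step, which a plain 2-phenylethenyl group on compound 2 would help to separate. They also leave open how a morpholine or a carboxylic acid on the phenyl ring at this position would read.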